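A few compounds are considered here, and "the series" means these few. Any claim that something is new, unique, unknown or untested is made for them only; others in the source may bear on it.

Compound 1 `Cn1nc2c(=O)n(CC3(O)CCN(Cc4ccc(-c5ccco5)cc4Cl)CC3)cnc2c1-c1ccc(C(N)=O)cc1` is the stronger of the two measured compounds in an assay on isolated protein for inhibition of ubiquitin carboxyl-terminal hydrolase 7 (Homo sapiens), with stated times of 30 min and 2 h (a higher number here means a weaker inhibitor, a lower number a stronger inhibitor), where compound 1 gives 80.8 nM. Among the compounds with values here, the only other measured compound, compound 2 `Cn1nc2c(=O)n(CC3(O)CCN(Cc4ccc(-c5ccc(C(=O)O)o5)cc4Cl)CC3)cnc2c1-c1ccc(CN)cc1`, differs from compound 1 in more than one place, and in this assay compound 2 gives 753 nM, a higher number than compound 1 by a margin that lies beyond the usual scatter. Within the data shown here, no step between compounds that differ in a single place is available, so the two values alone carry no lesson about any one change.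

The move to compound 3 `Cn1nc2c(=O)n(CC3(O)CCN(Cc4ccc(-c5ccco5)cc4Cl)CC3)cnc2c1-c1ccc(C(=N)N)cc1` is a single change on the shared core of compound 1: a group of 3 heavy atoms (1 carbon, 2 nitrogen; no ring) in place of a group of 3 heavy atoms (1 carbon, 1 nitrogen, 1 oxygen; no ring), on an aromatic carbon. The group that leaves, carbamoyl, and the group that enters both sit on an aromatic carbon of a six-membered aromatic ring of carbon only, para to a large group, and both count three heavy atoms; the entering group carries one more hydrogen-bond donor.

Among the measured compounds shown here, with no measured step of the same kind to lean on, the step from compound 1 to compound 3 is expected to be small and toward a somewhat higher number, of size a 1.9-fold higher number from compound 1 to compound 3 (0.27 log units; within the scatter), close to the edge of the scatter. Compound 3 is therefore estimated at 150 nM in this assay, with a range from 40 nM to 600 nM.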

Compound 3, half-maximal inhibitory concentration: 87.5 nM
Compound 3: middle estimate off by 1.7-fold (0.23 log units), on the high side, and the stated range covers the measured number.
By their numbers in this assay, from the lowest: compounds 1 and 3 (each within the scatter of the next); then compound 2.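

In this assay, exchanging carbamoyl for the entering group, on an aromatic carbon of a six-membered aromatic ring of carbon only, para to a large group, gives a 1.1-fold higher number from compound 1 to compound 3 (0.03 log units; within the scatter). Within the data shown here, this is the first step that isolates a single place, and it shows that this assay does not separate the two groups at this position, even though the entering group carries a second nitrogen in place of the oxygen and one more hydrogen-bond donor. Nothing shown here offers a reason for this result.

Among these compounds, what a nitrile, a sulfonamide or a methyl group would give on this same aromatic carbon remains open, so the single step does not define how much variation this position accepts. Also open, going by these compounds, is whether this exchange would read the same with other groups elsewhere on the shared core, and which of the places in which compound 1 and compound 2 differ accounts for the value of 753 nM in the latter.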